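A few compounds are considered here, and "the series" means these few. Any claim that something is new, unique, unknown or untested is made for them only; others in the source may bear on it.

Two compounds of the series carry a measured value. Compound 1, `O=C(Nc1ccc(Br)cc1)c1c(NCCO)cc(-c2cccc(Br)c2)oc1=O`, is one of them; in an ADME assay on Huh-7 cells (Homo sapiens) for cytotoxicity, with a stated time of 3 days (on this read-out higher numbers stand for lower toxicity in this test and lower numbers for higher toxicity in this test), compound 1 gives a value that is only a limit of the assay, > 20000 nM. Compound 2, `O=C(Nc1ccc(Br)cc1)c1c(NCCO)cc(-c2ccc(Br)cc2)oc1=O`, differs from compound 1 by 4-bromophenyl in place of 3-bromophenyl on an aromatic carbon. In this assay compound 2 likewise gives only a limit, > 20000 nM. The step that the two limits leave unreadable from compound 1 to compound 2 therefore cannot be read. Both values sit at the limit of > 20000 nM in this assay, at which 2 of the 2 values shown sit, so compound 2 stands at the limit with no number of its own.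

Compound 3, `COc1cccc(NC(=O)c2c(NCCO)cc(-c3ccc(Br)cc3)oc2=O)c1`, is not yet measured. Against compound 2 the change is 3-methoxyphenyl in place of 4-bromophenyl on an amide-type nitrogen. Among the compounds with values here, no measured step bears on it: the only step between measured compounds, the one from compound 1 to compound 2, is unreadable and concerns a different place. Nothing therefore points to a step beyond the scatter in either direction, and the expectation is that compound 3 again sits at the limit. The step that the limit leaves unreadable from compound 2 to compound 3 is expected to be small. Compound 3 is estimated at 25000 nM, within 10000 nM to 80000 nM, with a limit once more the likely outcome.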

Compound 3, half-maximal cytotoxic concentration: > 20000 nM
Compound 3: only a limit was reported; the forecaster's own chance of this, stated with the estimate: 75%; the middle value does not contradict the limit.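

Compound 3 gives only a limit of the assay, > 20000 nM. With compound 2 also at a limit, no step from compound 2 to compound 3 can be read: the limit of > 20000 nM in this assay, at which 3 of the 3 values shown sit.

The compounds shown leave open whether any change on the shared core moves the half-maximal cytotoxic concentration to a value that can be read as a number.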